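Compound 3 to compound 4: replacing the phenoxymethyl group

The source may report more compounds than this note shows. Statements on the series, on what has been measured and on what is new or still open speak of the compounds shown alone.

Within the data shown here, in an ADME assay on HepG2 cells (Homo sapiens) for cytotoxicity, read by MTT assay, with a stated time of 72 h (a lower number here means that less compound is tolerated, a higher number that more compound is tolerated), compound 3 (`O=[N+]([O-])c1c(CS(=O)(=O)c2ccccc2)nc2c(C#CCOc3ccccc3)cc(Cl)cn12`) gives 8400 nM, the only number in the set. Compound 1 (`COc1cccc(C#Cc2cc(Cl)cn3c([N+](=O)[O-])c(CS(=O)(=O)c4ccccc4)nc23)c1`) reaches only a limit, > 3900 nM. Compound 2 (`O=[N+]([O-])c1c(CS(=O)(=O)c2ccccc2)nc2c(C#Cc3ccc(F)cc3)cc(Cl)cn12`) also reaches only a limit, > 3900 nM.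

Compound 4 (`CC(C)(O)C#Cc1cc(Cl)cn2c([N+](=O)[O-])c(CS(=O)(=O)c3ccccc3)nc12`) carries 1-hydroxy-1-methylethyl in place of phenoxymethyl on a triple-bonded carbon. The steps at this same place, a step that the limit leaves unreadable from compound 1 to compound 3 and a step that the limit leaves unreadable from compound 2 to compound 3, give no size because of the limit of > 3900 nM in this assay, at which 2 of the 3 values shown sit. With no measured size to draw on, no change beyond the usual scatter is expected in this assay, and the expected step is a 1.3-fold higher number from compound 3 to compound 4 (0.12 log units; within the scatter). For compound 4 the estimate is 11000 nM, with an expected range of 4000 nM to 45000 nM.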

Compound 4, half-maximal cytotoxic concentration: > 62500 nM
Compound 4 ended at the assay's limit; the forecaster's own chance of this, stated with the estimate: 35%; middle value at least 5.6-fold (0.75 log units) from the limit.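

In this assay, this place on the triple-bonded carbon now gives a readable change, with an at least 7.4-fold higher number from compound 3 to compound 4 (0.87 log units; beyond the scatter). The change removes the six-membered aromatic ring of phenoxymethyl and brings in the hydrogen-bond donor of 1-hydroxy-1-methylethyl, so the group held here can move the tolerated concentration beyond the scatter. The steps from compound 1 and compound 2 to compound 4 cannot be read because of a limit: the limit of > 3900 nM in this assay, at which 2 of the 4 values shown sit.

On these data alone, whether the ring's removal or the entering hydroxyl carries the step stays open. A tert-butyl group at this place, with no hydroxyl, would separate the two.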